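Pyrrole for chlorophenyl on a quinoline amide

A few compounds are considered here, and "the series" means these few. Any claim that something is new, unique, unknown or untested is made for them only; others in the source may bear on it.

Compound 1 `CCN1CCN(c2cc(C)c3cc(NC(=O)c4ccc(Cl)cc4)ccc3n2)CC1`: 1530 nM
Compound 2 `Cc1cc(NCCN2CCCC2)nc2ccc(NC(=O)c3ccc(Cl)c(Cl)c3)cc12`: 1280 nM

Two compounds carry measured numbers in a functional assay on MCF7 cells (Homo sapiens) for antiproliferative activity, read by MTT assay, with a stated time of 72 h; on this read-out lower numbers stand for stronger inhibition and higher numbers for weaker inhibition. Compound 1 gives 1530 nM and compound 2 gives 1280 nM. Compound 1 stands at the higher of the two numbers, but its nearest neighbour, compound 2, sits so close that the gap lies within the scatter of repeated measurements, so no order between them can be claimed.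

The step considered here leads from compound 1 to compound 3 `CCN1CCN(c2cc(C)c3cc(NC(=O)c4ccc[nH]4)ccc3n2)CC1`. The difference is 1H-pyrrol-2-yl in place of 4-chlorophenyl on a carbonyl carbon. For the measured compounds named here, no measured pair in this set shows the effect of such an exchange, so the direction of the step can only be anticipated, not read off.

On the numbers shown, the author expects compound 3 to come out somewhat weaker than compound 1, with a step of a 1.6-fold higher number from compound 1 to compound 3 (0.21 log units; within the scatter) that may be modest and not far beyond the scatter. Compound 3 is therefore estimated at 2500 nM in this assay, within a range from 900 nM to 7000 nM.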

Compound 3, half-maximal inhibitory concentration: 14700 nM
For compound 3 the middle estimate is 5.9-fold (0.77 log units) below the measured one; the measured number lies above the stated range.
By their numbers in this assay, from the lowest: compounds 2 and 1 (each within the scatter of the next); then compound 3.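

Compound 1 and compound 2 differ in more than one place, so they said nothing about what the group on the carbonyl carbon contributes. In this assay, replacing 4-chlorophenyl with 1H-pyrrol-2-yl at this place, with the amide-type nitrogen and the rest of the molecule unchanged, gives a 9.6-fold higher number from compound 1 to compound 3 (0.98 log units; beyond the scatter), which shows that the read-out is sensitive to the group held here. This single exchange removes the chlorine, changes a six-membered aromatic ring to a five-membered one and adds a hydrogen-bond donor, and nothing available shows which of these changes accounts for the step.

A plain phenyl group on the same carbonyl carbon would separate the loss of the chlorine from the change of ring, while a 1-methylpyrrol-2-yl group or a 2-thienyl group would show whether the ring's hydrogen-bearing nitrogen matters. Going by these compounds, whether the exchange has a step of similar size on the core of compound 2, with its pyrrolidinylethylamino side chain, also remains open.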